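The source may report more compounds than this note shows. Statements on the series, on what has been measured and on what is new or still open speak of the compounds shown alone.

Measured so far in a functional assay on UO-31 cells (Homo sapiens) for inhibition, read by sulforhodamine B assay, with a stated time of 48 h; on this read-out lower numbers stand for higher toxicity in this test and higher numbers for lower toxicity in this test:
Compound 1 `O=C(Nc1cccc(-n2cc(-c3ccncc3)c(-c3ccc(Cl)c(O)c3)n2)c1)Nc1cccc(C(F)(F)F)c1`: > 32500 nM
Compound 2 `COc1cc(-c2nn(-c3cccc(NC(=O)c4cccc(C(F)(F)F)c4)c3)cc2-c2ccncc2)ccc1Cl`: > 50000 nM

Compound 2 stands at > 50000 nM, and this is a limit of the assay, not a number. Compound 1 likewise gives only a limit, > 32500 nM. Neither compound therefore has an exact lethal concentration.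

Compound 3 `COc1cc(-c2nn(-c3cccc(NC(=O)c4ccccc4)c3)cc2-c2ccncc2)ccc1Cl` keeps the shared core of compound 2 and changes it in one place, with hydrogen in place of trifluoromethyl on an aromatic carbon, meta to a large group: hydrogen in place of trifluoromethyl on an aromatic carbon. Put another way, 3-(trifluoromethyl)phenyl becomes phenyl.

Within the data shown here, no two measured compounds differ in only one place, so no measured step can serve as a guide. The expectation in this assay is no change beyond the usual scatter, in either direction, and compound 3 may well give only a limit too. The estimated change is small: a number no higher from compound 2 to compound 3 (the limit leaves the size open). For compound 3 the expected value is 50000 nM, with an estimated range from 20000 nM to 100000 nM.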

Compound 3, concentration lethal to 50% of the cells: > 100000 nM
Compound 3: only a limit was reported; the forecaster's own chance of this, stated with the estimate: 75%; middle value at least 2.0-fold (0.30 log units) from the limit.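

In this assay compound 3 gives > 100000 nM, which is a limit of the assay and not a number. Compound 2 also gives only a limit, and no step can be read between compound 2 and compound 3. The compounds shown leave open whether hydrogen in place of trifluoromethyl changes the lethal concentration at all, and by how much.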